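The source may hold more compounds than are shown below. What is called first, only, known or untested is meant among the compounds shown, and "the series" means these compounds.

Measured in an ADME assay on L02 cells (Homo sapiens) for cytotoxicity, read by MTT assay, with a stated time of 48 h; on this read-out lower numbers stand for stronger inhibition and higher numbers for weaker inhibition:
- Compound 1 `CCn1c(C(=O)NCCCN(C)C)ccc1C(CC)(CC)c1ccc(OCC(O)C(C)(C)C)c(C)c1`: 470 nM
- Compound 2 `C#CCNC(=O)c1ccc(C(CC)(CC)c2ccc(OCC(O)C(C)(C)C)c(C)c2)n1CC`: 4400 nM
- Compound 3 `CCn1c(C(=O)N(CCC#N)CCC#N)ccc1C(CC)(CC)c1ccc(OCC(O)C(C)(C)C)c(C)c1`: 1700 nM

Compound 3 stands in the middle of these three numbers. Compound 4 `C#CC(C)OC(=O)c1ccc(C(CC)(CC)c2ccc(OCC(O)C(C)(C)C)c(C)c2)n1CC` alters one place, on a carbonyl carbon: a group of 5 heavy atoms (4 carbon, 1 oxygen; no ring) in place of a group of 9 heavy atoms (6 carbon, 3 nitrogen; no ring), on a carbonyl carbon. The entering (1-methylprop-2-yn-1-yl)oxy group keeps a triple bond, and compound 2 also has one in its group on that carbonyl. The closest measured guide is therefore a 2.6-fold lower number from compound 2 to compound 3 (0.41 log units; beyond the scatter), a modest step. The wider steps, a 9.4-fold higher number from compound 1 to compound 2 (0.97 log units; beyond the scatter) and a 3.6-fold higher number from compound 1 to compound 3 (0.56 log units; beyond the scatter), are also modest. For the measured compounds named here, no measured compound has an oxygen on that carbonyl, so the uncertainty is wide. A modest rise in the number is expected, and the estimated step is a 2.4-fold higher number from compound 3 to compound 4 (0.37 log units; beyond the scatter). For compound 4 the estimate is 4000 nM, with an expected range of 1500 nM to 11000 nM.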

Compound 4, half-maximal inhibitory concentration: 23700 nM
For compound 4 the middle estimate is 5.9-fold (0.77 log units) below the measured one; measured number above the stated range.
By their numbers in this assay, from the lowest: compound 1; then compound 3; then compound 2; then compound 4.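

In this assay, the (1-methylprop-2-yn-1-yl)oxy group is the only group shown that joins this carbonyl carbon through oxygen, and it gives the highest number of the set (a 14-fold higher number from compound 3 to compound 4 (1.14 log units; beyond the scatter)) and (a 50-fold higher number from compound 1 to compound 4 (1.70 log units; beyond the scatter)). The number also rises against propargylamino, which has a triple bond too (a 5.4-fold higher number from compound 2 to compound 4 (0.73 log units; beyond the scatter)), so a shared triple bond does not keep the numbers close here. No measured evidence explains this rise. Still open, from the compounds shown here alone, is whether the oxygen link or the extra methyl matters more, and how a methoxy group or a carboxylic acid would read at this carbonyl carbon.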